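The compounds below may be only part of what the source reports. "The series", "measured", "known", "first", "only" and "open" are said of these compounds alone.

Working notes on the series sharing the core of compound 1 `CS(=O)(=O)c1ccc(Cc2n[nH]c(=S)n2/N=C/c2cccnc2)cc1`, read in a functional assay on HeLa cells (Homo sapiens) for cytotoxicity, read by MTT assay, with a stated time of 48 h, tested at 100 uM; a lower number here means a weaker effect, a higher number a stronger effect of the compound at the concentration tested.

Compound 1 gives 45.1%. Compound 2 `CS(=O)(=O)c1ccc(Cc2n[nH]c(=S)n2/N=C/c2ccc(Cl)cc2)cc1` gives 57%, and compound 3 `CS(=O)(=O)c1ccc(Cc2n[nH]c(=S)n2/N=C/c2c(F)cccc2Cl)cc1` gives 77.3%. Compound 3 thus stands highest of the three measured numbers, beyond the scatter against both others; the nearest is compound 2, the furthest compound 1.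

The next member is compound 4 `CS(=O)(=O)c1ccc(Cc2n[nH]c(=S)n2/N=C/c2ccc(F)cc2)cc1`. It differs from compound 3 in one place: 4-fluorophenyl in place of 2-chloro-6-fluorophenyl on a carbon with a double bond to nitrogen.

Of the measured steps, the one that bears most directly on this change is a number 20.3 percentage points higher from compound 2 to compound 3 (beyond the scatter), since compound 2 carries a single halogen on that aryl group, as compound 4 does. The other two steps, a number 11.9 percentage points higher from compound 1 to compound 2 (beyond the scatter) and a number 32.2 percentage points higher from compound 1 to compound 3 (beyond the scatter), show the same ordering of the aryl groups. Removing the 2-chloro-6-fluorophenyl group and entering 4-fluorophenyl is therefore expected to undo most of the gain seen from compound 2 to compound 3, and a downward step of modest size, beyond the scatter, is expected: a number 25.3 percentage points lower from compound 3 to compound 4 (beyond the scatter).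

For compound 4 the estimate in this assay is 52%, with a likely range from 35% to 70%.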

Compound 4, a percentage reported as activity, at one concentration (the size of the read-out at that concentration, not a potency): 57.8%
Beside the measured number, compound 4's estimate is 5.8 percentage points below it; low and high end bracket the measured number.
By their numbers in this assay, from the lowest: compound 1; then compounds 2 and 4 (each within the scatter of the next); then compound 3.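

In this assay, 4-fluorophenyl in place of 2-chloro-6-fluorophenyl on a carbon with a double bond to nitrogen gives a number 19.5 percentage points lower from compound 3 to compound 4 (beyond the scatter), so a second aryl group carrying a single halogen also falls short of compound 3, which stands beyond the scatter against all three other compounds. Fluoro in place of chloro on an aromatic carbon gives a number 0.8 percentage points higher from compound 2 to compound 4 (within the scatter), so this pair does not separate the two halogens, while a number 12.7 percentage points higher from compound 1 to compound 4 (beyond the scatter) shows that 4-fluorophenyl, like 4-chlorophenyl, reads above pyridin-3-yl. Nothing available explains these differences.

The compounds shown leave open whether the number of compound 3 follows from the presence of both halogens on one ring or from their placement, a question that a 2-fluorophenyl or a 2,6-dichlorophenyl group would bear on. They also leave open how non-halogen groups such as methoxy or an amine on the phenyl ring would read against the halogenated compounds.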